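Second ortho methyl on the aryl ether of compound 1

This account rests on a few compounds, and the source may have more. Where it says the series, first, only, none or still open, it means among the compounds named here.

Measured compounds:
compound 1 `Cc1ccccc1Oc1ccc(N2C[C@@H](C(F)(F)F)C[C@H]2CC(=O)O)cc1` with 330 nM
compound 2 `Cc1ccccc1Oc1ccc(N2CCC[C@H]2CC(=O)O)cc1` with 5600 nM
compound 3 `Cc1ccccc1C(=O)c1ccc(N2CCC[C@H]2CC(=O)O)cc1` with > 33000 nM

The read-out throughout is a functional assay on cells for agonist activity at Free fatty acid receptor 1 (Mus musculus), read by FLIPR and calcium flux, with a stated time of 100 s; on this read-out higher numbers stand for an effect only at larger amounts of compound and lower numbers for an effect already at smaller amounts. Compound 1 gives the lowest of the two numbers shown; the nearest is compound 2, reached by a 17-fold higher number from compound 1 to compound 2 (1.23 log units; beyond the scatter), the change being hydrogen in place of trifluoromethyl on a saturated ring carbon. For compound 3 only a limit of the assay is known, (the limit of > 33000 nM in this assay, at which 1 of the 3 values shown sits); it reports no number.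

Compound 4 `Cc1cccc(C)c1Oc1ccc(N2C[C@@H](C(F)(F)F)C[C@H]2CC(=O)O)cc1` differs from compound 1 by methyl in place of hydrogen on an aromatic carbon, turning 2-methylphenoxy into 2,6-dimethylphenoxy. For the measured compounds named here, none of the measured steps touches this part of the molecule: the single step measured concerns the saturated ring, and the pair of compound 2 and compound 3 shows only that swapping the ether linker for a carbonyl moves the value from a number to a limit. There is therefore no direct guide, and the expected change is a 1.1-fold lower number from compound 1 to compound 4 (0.04 log units; within the scatter), a step not beyond the scatter. For compound 4 the expected value is 300 nM, with a range from 100 nM to 1000 nM.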

Compound 4, half-maximal effective concentration: 270 nM
For compound 4 the middle estimate is 1.1-fold (0.05 log units) above the measured one, within the range that was stated.
By their numbers in this assay, from the lowest: compounds 4 and 1 (each within the scatter of the next); then compound 2. At a limit, above all of these: compound 3.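

In this assay the second methyl, which turns 2-methylphenoxy into 2,6-dimethylphenoxy, gives a 1.2-fold lower number from compound 1 to compound 4 (0.09 log units; within the scatter) and so leaves compound 1 and compound 4 indistinguishable. For the compounds shown here, this is the first reading on this part of the molecule, and it shows that this spot on the aromatic ring accepts one more methyl with no step beyond the scatter. The only earlier step, a 17-fold higher number from compound 1 to compound 2 (1.23 log units; beyond the scatter) and thus beyond the scatter, concerned the saturated ring and said nothing about this aromatic position, and nothing measured among these compounds offers a reason for the new result.

The compounds shown leave open whether this position would accept anything other than methyl, such as a chlorine atom, a methoxy group or a longer chain like isopropyl. As far as these compounds go, they also leave open whether 2,6-dimethylphenoxy would behave the same way on the core of compound 2, which carries hydrogen in place of trifluoromethyl, so it remains unknown whether the two changes act independently of each other.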